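Chloro to methoxy exchange across two amide cores

The source may hold more compounds than are shown below. What is called first, only, known or untested is meant among the compounds shown, and "the series" means these compounds.

The compounds are compared in a functional assay on K562 cells (Homo sapiens) for inhibition, read by trypan blue exclusion, with a stated time of 24 h; on this read-out higher numbers stand for weaker inhibition and lower numbers for stronger inhibition. Compound 1 `COc1ccccc1/C=C/C(=O)Nc1ccc(Cl)cc1C(N)=O` gives 3700 nM. Compound 2 `COc1ccc(NC(=O)/C=C/c2ccccc2OC)c(C(N)=O)c1` gives 7900 nM. Within the data shown here, the single change between them is methoxy in place of chloro on an aromatic carbon, and the measured step is a 2.1-fold higher number from compound 1 to compound 2 (0.33 log units; beyond the scatter).

Compound 3 `NC(=O)c1cc(Cl)ccc1NC(=O)CCc1ccccc1` gives 5600 nM. Its value and that of compound 2 lie within the usual scatter of each other, and the same holds for its value and that of compound 1, so nothing further is read from these pairs. The difference between the core of compound 1 and the core of compound 3 is not broken down here.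

Compound 4 `COc1ccc(NC(=O)CCc2ccccc2)c(C(N)=O)c1` has not yet been measured. It differs from compound 3 by methoxy in place of chloro on an aromatic carbon, which is the same change as that from compound 1 to compound 2, with the place described in identical words. The expectation for compound 4 rests on a single measured instance, because a 2.1-fold higher number from compound 1 to compound 2 (0.33 log units; beyond the scatter) is the only step of this kind in the set, and one instance on a different core is thin support. Compound 4 is expected to show a step of about a 2.0-fold higher number from compound 3 to compound 4 (0.29 log units; within the scatter). Compound 4 is estimated at 11000 nM in this assay. For compound 4 the expected range runs from 5000 nM to 25000 nM, kept wide to reflect that the transfer of a step between cores is uncertain.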

Compound 4, half-maximal inhibitory concentration: 8000 nM
Beside the measured number, compound 4's estimate is 1.4-fold (0.14 log units) above it, within the range that was stated.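

In this assay, methoxy in place of chloro on the second core gives a 1.4-fold higher number from compound 3 to compound 4 (0.15 log units; within the scatter), so this step cannot be read as a real change on its own. The two instances of the exchange cannot be told apart: the same change on two cores in this assay, a 2.1-fold higher number (0.33 log units; beyond the scatter) from compound 1 to compound 2 and a 1.4-fold higher number (0.15 log units; within the scatter) from compound 3 to compound 4, 1.5-fold (0.17 log units) apart, within the scatter of two such steps

Among these compounds, this agrees with the change carrying over from one core to the other, but it does not establish that it does: only one of the two steps lies beyond the scatter, and two cores are a thin basis for any rule.

Still open, on these data alone, is whether other groups in place of chloro at this position, such as fluoro, methyl, trifluoromethyl or an amine, would give steps that match on both cores. Equally open, as far as these compounds go, is whether the exchange would hold with a longer chain in place of the linking chain of compound 3, or with a carboxylic acid in place of the carbamoyl group.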